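A few compounds are considered here, and "the series" means these few. Any claim that something is new, unique, unknown or untested is made for them only; others in the source may bear on it.

Measured compounds in a functional assay on DU-145 cells (Homo sapiens) for inhibition, read by MTT assay, with a stated time of 24 h; on this read-out higher numbers stand for weaker inhibition and lower numbers for stronger inhibition:
- compound 1, `CCOC(=O)C1=Cc2ccccc2OC1(OCc1cn(CC(=O)Nc2ccccc2F)nn1)C(F)(F)F`, gives 33900 nM
- compound 2, `CCOC(=O)C1=Cc2ccccc2OC1(OCc1cn(-c2ccc(F)c(Cl)c2)nn1)C(F)(F)F`, gives 21500 nM

Among the measured compounds shown here, compound 2 holds the lowest of the two numbers in this assay, and its only neighbour is compound 1, from which it is separated by a 1.6-fold lower number from compound 1 to compound 2 (0.20 log units; within the scatter). The unmeasured compound 3, `CCOC(=O)C1=Cc2ccccc2OC1(OCc1cn(-c2ccc(C)cc2)nn1)C(F)(F)F`, differs from compound 2 in one place: 4-methylphenyl in place of 3-chloro-4-fluorophenyl on an aromatic nitrogen.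

For the measured compounds named here, no measured step bears directly on an aryl-to-aryl swap on the ring nitrogen. Going by the values given here, the single step on record, a 1.6-fold lower number from compound 1 to compound 2 (0.20 log units; within the scatter), replaced an alkyl amide chain with an aryl group and stayed within the scatter. Two aryl groups of similar size on the same nitrogen are therefore expected to give numbers not far apart, with no step beyond the scatter in either direction.

For compound 3 in this assay, the estimate is 25000 nM, within 10000 nM to 60000 nM. This estimate corresponds to an expected step of a 1.2-fold higher number from compound 2 to compound 3 (0.07 log units; within the scatter).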

Compound 3, half-maximal inhibitory concentration: 30200 nM
The estimate for compound 3 lay 1.2-fold (0.08 log units) below the measured number, within the range that was stated.
By their numbers in this assay, from the lowest: compounds 2, 3 and 1 (each within the scatter of the next).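

Working notes: in this assay, this aryl-for-aryl swap on the aromatic nitrogen gives a 1.4-fold higher number from compound 2 to compound 3 (0.15 log units; within the scatter), so the series does not separate 4-methylphenyl, with carbon only, from 3-chloro-4-fluorophenyl, with its chlorine and fluorine. The comparison with the amide-bearing chain gives a 1.1-fold lower number from compound 1 to compound 3 (0.05 log units; within the scatter), so a second aryl group also stays within the scatter of ((2-fluorophenyl)carbamoyl)methyl, and all three groups at this position now sit within the scatter of one another. Nothing available explains why these numbers lie so close together.

On these data alone, it remains open whether a group of another kind on this nitrogen, such as a carboxylic acid or a longer chain ending in an amine, would produce a step beyond the scatter. The compounds shown also leave open how replacing the ethyl ester or the trifluoromethyl on the shared core would affect the read-out.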